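Swapping bromo for methyl on the shared core

The source may report more compounds than this note shows. Statements on the series, on what has been measured and on what is new or still open speak of the compounds shown alone.

Compound 1 `CN1C(=O)C(O)(Cc2nnn[nH]2)c2cc(F)ccc21` – > 100000 nM (a limit, not a number)
Compound 2 `CN1C(=O)C(O)(Cc2nnn[nH]2)c2cc(Cl)ccc21` – > 100000 nM (a limit, not a number)
Compound 3 `CN1C(=O)C(O)(Cc2nnn[nH]2)c2cc(Br)ccc21` – 67300 nM

Among the compounds with values here, in a functional assay on MDA-MB-231 cells (Homo sapiens) for antiproliferative activity, read by MTT assay, with a stated time of 48 h (on this read-out lower numbers stand for stronger inhibition and higher numbers for weaker inhibition), compound 3 gives 67300 nM as the only true number here. Compound 1 and compound 2 both sit at the limit of > 100000 nM in this assay, at which 2 of the 3 values shown sit, and so show no exact value.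

Compound 4 `Cc1ccc2c(c1)C(O)(Cc1nnn[nH]1)C(=O)N2C` has methyl in place of bromo on an aromatic carbon. The closest evidence is two other swaps on an aromatic carbon: an at least 1.4-fold lower number from compound 1 to compound 3 (0.17 log units; that floor lies within the scatter) and an at least 1.4-fold lower number from compound 2 to compound 3 (0.17 log units; that floor lies within the scatter). Both are only floors, so they give little guidance. A small rise, perhaps reaching the limit, is expected. The estimated step is a 1.3-fold higher number from compound 3 to compound 4 (0.13 log units; within the scatter) and is expected to stay within the scatter. For compound 4 the estimate is 90000 nM, with an expected range from 45000 nM to 180000 nM.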

Compound 4, half-maximal inhibitory concentration: > 100000 nM
Compound 4: a limit, no number; the forecaster's own chance of this, stated with the estimate: 55%; middle value at least 1.1-fold (0.04 log units) away from the limit.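

Methyl is the first group at this position that is not a halogen, and in this assay it gives no readable number. The step is an at least 1.4-fold higher number from compound 3 to compound 4 (0.17 log units; that floor lies within the scatter), so only a floor is known, and that floor does not separate the two compounds. Bromo remains the only group here with a true number, and the steps among compound 1, compound 2 and compound 4 cannot be read: the limit of > 100000 nM in this assay, at which 3 of the 4 values shown sit.

On these data alone, the true values behind these limits stay unknown. As far as these compounds go, whether a methoxy group or an amine on this carbon would give a number also stays open.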